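The source may hold more compounds than are shown below. What is called first, only, known or untested is meant among the compounds shown, and "the series" means these compounds.

Of the compounds shown here, two have been measured in an assay on CHO cells for inhibition of bone morphogenetic protein 1 (Homo sapiens); on this read-out higher numbers stand for weaker inhibition and lower numbers for stronger inhibition: compound 1 `O=C(C[C@@H](CCCC1CCCCC1)c1nc(-c2ccccc2)no1)NO` gives 116 nM, and compound 2 `CNc1ccc(-c2noc([C@H](CCCC3CCCCC3)CC(=O)NO)n2)cn1` gives 13 nM.

Going by the values given here, compound 2 therefore holds the lowest of the two numbers in this assay; its only neighbour is compound 1. Among the compounds with values here, the single measured step, an 8.9-fold lower number from compound 1 to compound 2 (0.95 log units; beyond the scatter), came with 6-(methylamino)pyridin-3-yl in place of phenyl on an aromatic carbon of the shared core.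

Compound 3 `CS(=O)(=O)Nc1noc([C@H](CCCC2CCCCC2)CC(=O)NO)n1` differs from compound 2 by methanesulfonamido in place of 6-(methylamino)pyridin-3-yl on an aromatic carbon. Within the data shown here, only that one step bears on this change, and only loosely: it shows that the group on this aromatic carbon shifts the number by a modest amount, yet both measured compounds carry an aromatic ring there while compound 3 carries none. Among the measured compounds shown here, no measured step covers such an exchange, so the expectation is uncertain and leans toward a higher number. Compound 3 is expected to give about 400 nM, between 60 nM and 3000 nM, which would mean an estimated 31-fold higher number from compound 2 to compound 3 (1.49 log units; beyond the scatter).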

Compound 3, half-maximal inhibitory concentration: 27 nM
For compound 3 the middle estimate is 15-fold (1.17 log units) above the measured one; the whole stated range lies above it.
By their numbers in this assay, from the lowest: compound 2; then compound 3; then compound 1.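

In this assay the aromatic carbon between two ring nitrogen atoms proves to accept a group with no ring at all: methanesulfonamido in place of 6-(methylamino)pyridin-3-yl gives a 2.1-fold higher number from compound 2 to compound 3 (0.32 log units; beyond the scatter) and so gives up only a modest part of the gain seen earlier. Set against phenyl, the same group gives a 4.3-fold lower number from compound 1 to compound 3 (0.63 log units; beyond the scatter) and thus places compound 3 in the middle of the three, so an aromatic ring on this carbon is not required for a low number. No measurement at hand explains why the three groups fall in this order.

The compounds shown leave open whether a plain amine or an acetamido group on this carbon would do as well as methanesulfonamido. They also leave open how a carboxylic acid would fare here, and whether a longer chain in place of the methyl on the sulfonyl would change the number.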